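Swapping a carboxyphenyl for a carboxypyrimidinyl ring

The source may report more compounds than this note shows. Statements on the series, on what has been measured and on what is new or still open speak of the compounds shown alone.

Compound 2 `O=C(O)c1cccc(C2=C(c3cc(Cl)ccc3OCc3ccccc3)CCC2)c1` gives 5.01 nM in an assay on isolated protein for inhibition of prostaglandin E2 receptor EP1 subtype (Homo sapiens) (on this read-out lower numbers stand for stronger inhibition and higher numbers for weaker inhibition), the lowest of the two numbers recorded so far. Its nearest neighbour is compound 1 `O=C(O)c1cc(C2=C(c3cc(Cl)ccc3OCc3ccccc3)CCC2)ncn1`, which gives 200 nM in this assay; the two differ only in the aromatic ring that carries the carboxylic acid, and a 40-fold lower number from compound 1 to compound 2 (1.60 log units; beyond the scatter) describes that change. Compound 3 `O=C(O)c1ccnc(C2=C(c3cc(Cl)ccc3OCc3ccccc3)CCC2)n1` is not yet measured. It differs from compound 2 as follows: 4-carboxypyrimidin-2-yl in place of 3-carboxyphenyl on a double-bonded ring carbon. Within the data shown here, the only step that bears on this move is the one from compound 1 to compound 2, which runs in the opposite direction and was large. Returning from the carbon-only ring to a ring with two nitrogen atoms is therefore expected to raise the number well beyond the scatter, as a 30-fold higher number from compound 2 to compound 3 (1.48 log units; beyond the scatter) expresses. Compound 3 is thus estimated at 150 nM, within a range from 30 nM to 800 nM.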

Compound 3, half-maximal inhibitory concentration: 158 nM
Compound 3: middle estimate off by 1.1-fold (0.02 log units), on the low side, and the stated range covers the measured number.
By their numbers in this assay, from the lowest: compound 2; then compounds 3 and 1 (each within the scatter of the next).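

At this place on the double-bonded ring carbon, a second pyrimidine ring, 4-carboxypyrimidin-2-yl, also falls well short of the 3-carboxyphenyl ring: a 32-fold higher number from compound 2 to compound 3 (1.50 log units; beyond the scatter). The two pyrimidine rings themselves cannot be told apart on this read-out, with a 1.3-fold lower number from compound 1 to compound 3 (0.10 log units; within the scatter). Among these three compounds, then, only the ring of carbon atoms gives the low number, whichever of the two pyrimidine rings is set against it.

Nothing available accounts for the gap between the ring of carbon atoms and the pyrimidine rings. As far as these compounds go, it remains open whether a pyridine ring, with a single ring nitrogen, would give a number closer to that of compound 2 or that of compound 3, and whether a tetrazole in place of the carboxylic acid would keep the low number of compound 2.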